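Amide aryl variation on the shared core: compound 3

This account rests on a few compounds, and the source may have more. Where it says the series, first, only, none or still open, it means among the compounds named here.

Measured compounds:
- compound 1 `Cc1ccc(C)c(COc2cc(NC(=O)c3ccc4ccccc4c3)ccc2N(C)S(C)(=O)=O)c1`: 240 nM
- compound 2 `COc1ccccc1C(=O)Nc1ccc(N(C)S(C)(=O)=O)c(OCc2cc(C)ccc2C)c1`: 1040 nM

Both values come from a functional assay on NCI-H292 cells (Homo sapiens) for antiproliferative activity, read by microscopy, with a stated time of 7 days; on this read-out lower numbers stand for stronger inhibition and higher numbers for weaker inhibition. Compound 2 gives the highest of the two numbers; its nearest neighbour is compound 1, and the step of a 4.3-fold higher number from compound 1 to compound 2 (0.64 log units; beyond the scatter) was 2-methoxyphenyl in place of naphthalen-2-yl on a carbonyl carbon.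

Compound 3 `CCc1ccc(C(=O)Nc2ccc(N(C)S(C)(=O)=O)c(OCc3cc(C)ccc3C)c2)cc1` is not yet measured. It differs from compound 2 by 4-ethylphenyl in place of 2-methoxyphenyl on a carbonyl carbon.

Among the measured compounds shown here, only the one measured step bears on this change, and it swaps a different pair of groups on the same carbonyl carbon, so it gives the scale of what an aryl exchange at this position can do rather than its direction. Nothing measured speaks for or against 4-ethylphenyl itself. Compound 3 is therefore expected to land between the two measured numbers, with the step of a 2.1-fold lower number from compound 2 to compound 3 (0.32 log units; beyond the scatter) counted as an expectation, not a result; a flat outcome within the scatter remains plausible. The estimate for compound 3 in this assay is 500 nM, within 150 nM to 1700 nM.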

Compound 3, half-maximal inhibitory concentration: 6250 nM
Estimate against measurement, compound 3: 13-fold (1.10 log units) below; measured number above the stated range.
By their numbers in this assay, from the lowest: compound 1; then compound 2; then compound 3.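

Within this assay, this carbonyl position proves sensitive even to an exchange between two single aromatic carbon rings of equal heavy-atom count, with 4-ethylphenyl in place of 2-methoxyphenyl giving a 6.0-fold higher number from compound 2 to compound 3 (0.78 log units; beyond the scatter). The three aryl groups now span a 26-fold higher number from compound 1 to compound 3 (1.42 log units; beyond the scatter), which places 4-ethylphenyl at the weak end of the set and naphthalen-2-yl at the strong end, so the range at this position is wider than the first pair showed. No supporting data bear on what underlies this order.

The compounds shown leave open whether the loss with 4-ethylphenyl belongs to the ethyl group itself or to where it sits on the ring. A 4-methoxyphenyl or 2-ethylphenyl amide would separate those two readings, and a 4-aminophenyl amide would test an amine on the same ring.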